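The compounds below may be only part of what the source reports. "The series", "measured", "known", "first", "only" and "open" are said of these compounds alone.

Compound 1 `CCCCCNc1cccc2c(S(=O)(=O)Nc3onc(C)c3C)cccc12` gives 80 nM in an assay on VSM-A10 cells for antagonist activity at Endothelin-1 receptor (Rattus norvegicus); on this read-out higher numbers stand for weaker inhibition and lower numbers for stronger inhibition.
Compound 2 `CCCNc1ccc(S(=O)(=O)Nc2onc(C)c2C)cc1` gives 27000 nM in this assay.
Compound 3 `Cc1noc(NS(=O)(=O)c2cccc3c(NCCCCCc4ccccc4)cccc23)c1C` gives 3050 nM in this assay.

Among these three, compound 2 stands at the highest number, beyond the scatter from both compound 3 and compound 1. Compound 4 `Cc1noc(NS(=O)(=O)c2ccc(NC(=O)CN)cc2)c1C` is not yet measured; it differs from compound 2 by (aminomethyl)carbonyl in place of propyl on a nitrogen on an aromatic ring. Going by the values given here, no measured pair shows this particular exchange. Among the compounds with values here, the one step that is known, a 38-fold higher number from compound 1 to compound 3 (1.58 log units; beyond the scatter), concerns a change on the saturated chain hanging from the same kind of ring nitrogen and was large; it shows that what sits on that nitrogen can move the number a great deal, but it gives no direction for the present change. With compound 2 already at the weak end, the expected outcome is a step of a 1.1-fold higher number from compound 2 to compound 4 (0.05 log units; within the scatter) in this assay, with wide uncertainty. Compound 4 is therefore estimated at 30000 nM, somewhere between 7000 nM and 120000 nM.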

Compound 4, half-maximal inhibitory concentration: 6500 nM
Compound 4: the middle estimate sits 4.6-fold (0.66 log units) above what was measured, and the stated range ends above it.
By their numbers in this assay, from the lowest: compound 1; then compound 3; then compound 4; then compound 2.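

Putting (aminomethyl)carbonyl in place of propyl on a nitrogen on an aromatic ring gives a 4.2-fold lower number from compound 2 to compound 4 (0.62 log units; beyond the scatter) in this assay. Going by these compounds alone, this is the first direct reading of a change at this nitrogen on the core of compound 2, and it gives the direction that the earlier step could not: the exchange lowers the number, and by more than the scatter, whereas the phenyl step on the saturated chain raised it. Nothing available explains this step.

As far as these compounds go, whether the lower number goes with the carbonyl or with the amine stays open, and a plain acetyl group on that nitrogen would separate the two. Also open, from the compounds shown here alone, is how a longer chain, such as pentyl, would read on the core of compound 2.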